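Trading the hydroxamic acid for a methylamide on the pyrrolopyridine series

The source may report more compounds than this note shows. Statements on the series, on what has been measured and on what is new or still open speak of the compounds shown alone.

Compound 1 `CNC(=O)CCCCCCCn1nc(-c2ccc3oc(N)nc3c2)c2c(N)ncnc21`: 10300 nM
Compound 2 `Nc1ncnc2c1c(-c1cnc3[nH]ccc3c1)nn2CCCCCCCCCC(=O)NO`: 17200 nM
Compound 3 `Nc1ncnc2c1c(-c1cnc3[nH]ccc3c1)nn2CCCCCC(=O)NO`: > 50000 nM

Of the compounds shown here, three have been measured in a functional assay on Hep 3B2 cells (Homo sapiens) for inhibition, read by MTT assay, with a stated time of 72 h; on this read-out higher numbers stand for weaker inhibition and lower numbers for stronger inhibition. Compound 1 gives 10300 nM. Compound 2 gives 17200 nM. For compound 3 the assay returns only a limit, > 50000 nM, so compound 3 stands at the weak end of the series without a number of its own. For the measured compounds named here, the one measured step, an at least 2.9-fold higher number from compound 2 to compound 3 (0.46 log units; beyond the scatter), shows that shortening the hydroxamic acid chain weakened inhibition, and compound 3 itself sits at the limit of > 50000 nM in this assay, at which 1 of the 3 values shown sits.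

Compound 4 `CNC(=O)CCCCCCCn1nc(-c2cnc3[nH]ccc3c2)c2c(N)ncnc21` differs from compound 3 by 2-(methylcarbamoyl)ethyl in place of hydroxycarbamoyl on a saturated chain carbon, five bonds along the chain from an aromatic nitrogen. Going by the values given here, no measured step covers this exchange directly. Compound 1 carries the same 2-(methylcarbamoyl)ethyl-terminated chain on a different core and gives 10300 nM, which suggests the methylamide series is not strongly active either. Since compound 3 is known only as a limit, any step from compound 3 to compound 4 cannot be sized from the data. The expectation for compound 4 is a weak value, likely above that of compound 1, estimated at 22000 nM with a range from 7000 nM to 60000 nM, corresponding to an expected step of an at least 2.2-fold lower number from compound 3 to compound 4 (0.35 log units; beyond the scatter).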

Compound 4, half-maximal inhibitory concentration: 16300 nM
For compound 4 the middle estimate is 1.3-fold (0.13 log units) above the measured one; low and high end bracket the measured number.
By their numbers in this assay, from the lowest: compounds 1, 4 and 2 (each within the scatter of the next). At a limit, above all of these: compound 3.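

In this assay, replacing hydroxycarbamoyl with 2-(methylcarbamoyl)ethyl on a saturated chain carbon, five bonds along the chain from an aromatic nitrogen, gives an at least 3.0-fold lower number from compound 3 to compound 4 (0.48 log units; beyond the scatter), so the longer methylamide chain restores a measurable value on this core. On these data alone, compound 3 has only a limit, so the true size of this step remains unknown: the limit of > 50000 nM in this assay, at which 1 of the 4 values shown sits. The hydroxamic acid is also not needed to reach this level, since a 1.1-fold lower number from compound 2 to compound 4 (0.02 log units; within the scatter) is within the scatter, as is a 1.6-fold higher number from compound 1 to compound 4 (0.20 log units; within the scatter), so compound 4 cannot be told apart from either compound 2 or compound 1.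

The compounds shown leave open whether a carboxylic acid or a primary amine at the chain end would read like the methylamide, and whether methylcarbamoyl on a shorter chain would lose its activity as the short hydroxamic acid chain of compound 3 does. They also leave open whether a hydroxycarbamoyl chain on the core of compound 1 would stay in the same range.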